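Trimming the chain of compound 1

The source may hold more compounds than are shown below. What is called first, only, known or untested is meant among the compounds shown, and "the series" means these compounds.

- compound 1 `CCCCCCCCCCCCCCCCCC(=O)N1CCOCC1` gives 33.1 ug/mL
- compound 2 `CCCCCCCCCCCCCCCCCC(=O)N[C@H](C)c1ccccc1` gives 25.7 ug/mL

For the measured compounds named here, in a functional assay on NCI/ADR-RES cells (Homo sapiens) for antiproliferative activity, read by sulforhodamine B assay, with a stated time of 48 h (a higher number here means a weaker inhibitor of growth, a lower number a stronger inhibitor of growth), compound 1 stands close to compound 2: the only measured step (a 1.3-fold lower number from compound 1 to compound 2 (0.11 log units; within the scatter)) changes the group on the carbonyl carbon and leaves the chain alone. Compound 3 `CCCCCCCCCCCCCCCC(=O)N1CCOCC1` has a shorter chain (hydrogen in place of ethyl on a saturated chain carbon, ten or more bonds along the chain from a carbonyl carbon), with hydrogen in place of ethyl on a saturated chain carbon, ten or more bonds along the chain from a carbonyl carbon. No measurement tests such a change, so no shift beyond the scatter is expected in this assay and the estimated step is small (a 1.1-fold lower number from compound 1 to compound 3 (0.04 log units; within the scatter)). Compound 3 is expected at 30 ug/mL (estimated range 14 ug/mL to 65 ug/mL).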

Compound 3, concentration for 50% growth inhibition: 6.2 ug/mL
Compound 3: the middle estimate sits 4.8-fold (0.68 log units) above what was measured; the measured number lies below the stated range.
By their numbers in this assay, from the lowest: compound 3; then compounds 2 and 1 (each within the scatter of the next).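

In this assay, the step of a 5.3-fold lower number from compound 1 to compound 3 (0.73 log units; beyond the scatter) shows that this chain position is not silent: hydrogen in place of ethyl on a saturated chain carbon, ten or more bonds along the chain from a carbonyl carbon, moves the number beyond the scatter. For the compounds shown here, the one earlier step, a change on the carbonyl carbon, did not do so. Nothing available explains this drop.

Going by these compounds, whether an even shorter chain or a longer chain would move the number further remains open. So does whether the (1-phenylethyl)amino group would give a similar number on the shorter chain.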